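Chain Lengthening on Two Cores in Ileum Antagonism

The source may report more compounds than this note shows. Statements on the series, on what has been measured and on what is new or still open speak of the compounds shown alone.

Measured compounds:
In a functional assay on ileum (Cavia porcellus) for antagonist activity, with a stated time of 30 s (a lower number here means a stronger inhibitor, a higher number a weaker inhibitor), compound 1 `O=C(O)c1cc(=O)c2cc(OCCCOc3ccccc3)ccc2o1` gives 3.3 ug/mL.
In this assay compound 2 `O=C(O)c1cc(=O)c2cc(OCCCCCOc3ccccc3)ccc2o1` gives 3.3 ug/mL.
In this assay compound 3 `O=C(O)c1cc(=O)c2ccc(OCCCOc3ccccc3)cc2o1` gives 1.4 ug/mL.

Compound 1 and compound 2 share a core and differ in one place: 2-phenoxyethyl in place of phenoxy on a saturated chain carbon, three bonds along the chain from an oxygen on an aromatic ring. That change gave no change at the digits printed from compound 1 to compound 2 (within the scatter), so the longer chain left the half-maximal inhibitory concentration where it was.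

Compound 3 has the same atoms as compound 1, joined differently; the difference between the two cores is not broken down here. Compound 3 holds the lowest number of the three, and its values against compound 1 and compound 2 both lie beyond the scatter, so among the measured compounds it is the strongest inhibitor.

Compound 4 `O=C(O)c1cc(=O)c2ccc(OCCCCCOc3ccccc3)cc2o1` has not yet been measured. It stands to compound 3 as compound 2 stands to compound 1: 2-phenoxyethyl in place of phenoxy on a saturated chain carbon, three bonds along the chain from an oxygen on an aromatic ring. Because the same change gave no change at the digits printed from compound 1 to compound 2 (within the scatter), the step from compound 3 to compound 4 is expected to be small, about no change at the digits printed from compound 3 to compound 4 (within the scatter). That expectation rests on a single earlier pair, and the core of compound 3 is not the core of compound 1, so it carries some uncertainty. For compound 4 in this assay the estimate is 1.4 ug/mL, expected to fall between 0.7 ug/mL and 3 ug/mL.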

Compound 4, half-maximal inhibitory concentration: 0.4 ug/mL
Estimate against measurement, compound 4: 3.5-fold (0.54 log units) above; the whole stated range lies above it.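

In this assay, 2-phenoxyethyl in place of phenoxy on the core of compound 3 gave a 3.5-fold lower number from compound 3 to compound 4 (0.54 log units; beyond the scatter), so the change did not carry over from one core to the other with the same size: the same change on two cores in this assay, no change at the digits printed (within the scatter) from compound 1 to compound 2 and a 3.5-fold lower number (0.54 log units; beyond the scatter) from compound 3 to compound 4, 3.5-fold (0.54 log units) apart, beyond the scatter of two such steps The same chain extension therefore left the half-maximal inhibitory concentration unmoved on the core of compound 1 but lowered it on the core of compound 3, and the outcome on one core would not have served as a reliable guide to the outcome on the other. Among these compounds, this rests on only two matched pairs, one kind of chain change and one assay, so it shows that the core matters here but not why, nor how general the difference is across other changes.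

The compounds shown leave open whether a longer chain than 2-phenoxyethyl would lower the number further on the core of compound 3, or would continue to leave it unmoved on the core of compound 1. They also leave open how either core would respond to a chlorine on the phenoxy ring, or to an amide in place of the carboxylic acid.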